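Swapping the Aryl Amide: Thiophene to Isoquinoline

This account rests on a few compounds, and the source may have more. Where it says the series, first, only, none or still open, it means among the compounds named here.

Compound 1, `CCCCCCCCCCCCNC(=O)[C@@H](NC(=O)c1nccc2ccccc12)[C@@H](C)O`: 65700 nM in a functional assay on HepG2 cells (Homo sapiens) for cytotoxicity, read by MTT assay, with a stated time of 48 h; on this read-out lower numbers stand for stronger inhibition and higher numbers for weaker inhibition
Compound 2, `CCCCCCCCCCCCCCNC(=O)[C@@H](NC(=O)c1ccccc1)[C@@H](C)O`: 54200 nM
Compound 3, `CCCCCCCCCCCCCCNC(=O)[C@@H](NC(=O)c1cccs1)[C@@H](C)O`: 88400 nM

The three numbers in this assay sit close together; compound 3 carries the largest of them, yet its gaps to compound 1 and compound 2 both fall within the scatter. Compound 4, `CCCCCCCCCCCCCCNC(=O)[C@@H](NC(=O)c1nccc2ccccc12)[C@@H](C)O`, differs from compound 3 by isoquinolin-1-yl in place of thiophen-2-yl on a carbonyl carbon. Within the data shown here, only one measured step touches this position, a 1.6-fold higher number from compound 2 to compound 3 (0.21 log units; within the scatter), and it stayed within the scatter. Compound 1 already bears the entering group on a shorter chain and its value in this assay is close to that of compound 3, so no step beyond the scatter is expected. Compound 4 is estimated at 65000 nM, ranging from 30000 nM to 140000 nM, an expected step of a 1.4-fold lower number from compound 3 to compound 4 (0.13 log units; within the scatter).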

Compound 4, half-maximal inhibitory concentration: 28600 nM
For compound 4 the middle estimate is 2.3-fold (0.36 log units) above the measured one, and the stated range ends above it.
By their numbers in this assay, from the lowest: compounds 4, 2, 1 and 3 (each within the scatter of the next, the first and the last beyond it).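

In this assay, among these compounds, isoquinolin-1-yl on the carbonyl carbon gives the only step at this position that lies beyond the scatter, a 3.1-fold lower number from compound 3 to compound 4 (0.49 log units; beyond the scatter), while the step against phenyl, a 1.9-fold lower number from compound 2 to compound 4 (0.28 log units; within the scatter), stays within it. Chain length also counts with this group in place: ethyl in place of hydrogen on the saturated chain gives a 2.3-fold lower number from compound 1 to compound 4 (0.36 log units; beyond the scatter). Nothing available bears on why these steps arise. The compounds shown leave open how an amine or a carboxylic acid on the carbonyl carbon would compare, and whether a longer chain would go further in the same direction.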